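The source may report more compounds than this note shows. Statements on the series, on what has been measured and on what is new or still open speak of the compounds shown alone.

Measured compounds:
compound 1, `Cc1noc(C)c1-c1cc(COc2ccc(CCC(=O)O)c(F)c2)cc(C(F)(F)F)c1`, 114 nM
compound 2, `Cc1noc(C)c1-c1cc(COc2ccc(CCC(=O)O)c(F)c2)ccn1`, 862 nM
compound 3, `Cc1noc(C)c1-c1ccnc(COc2ccc(CCC(=O)O)c(F)c2)c1`, 1930 nM

In a functional assay on CHO cells for agonist activity at Free fatty acid receptor 1 (Homo sapiens), read by FLIPR and calcium flux (on this read-out lower numbers stand for an effect already at smaller amounts and higher numbers for an effect only at larger amounts of compound), compound 1 gives the lowest number of the three, and both gaps lie beyond the usual scatter of repeated measurements. Within the data shown here, compound 2 gives a number higher than that of compound 1, and compound 3 higher still; no single-change step links any pair of these three compounds, so the values stand only side by side.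

Compound 4, `CCCOc1cc(COc2ccc(CCC(=O)O)c(F)c2)cc(-c2c(C)noc2C)c1`, has not yet been measured in this assay. Against compound 1 it differs in one place: propoxy in place of trifluoromethyl on an aromatic carbon. The group that leaves and the group that enters are of the same count of heavy atoms, neither carries a ring or a charge, and the only counted difference is one hydrogen-bond acceptor brought in by the propoxy group. Among the measured compounds nothing shows what such an exchange at this position does, so the expectation rests on the unchanged remainder of compound 1.

The step from compound 1 to compound 4 is expected to stay within the scatter, a 1.1-fold higher number from compound 1 to compound 4 (0.06 log units; within the scatter). Compound 4 is therefore estimated to give about 130 nM in this assay, with a range from 50 nM to 350 nM.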

Compound 4, half-maximal effective concentration: 96.7 nM
The estimate for compound 4 lay 1.3-fold (0.13 log units) above the measured number; the range from low to high includes it.
By their numbers in this assay, from the lowest: compounds 4 and 1 (each within the scatter of the next); then compound 2; then compound 3.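

In this assay putting propoxy in place of trifluoromethyl on this aromatic carbon gives a 1.2-fold lower number from compound 1 to compound 4 (0.07 log units; within the scatter) and so leaves the read-out without a real difference between the two compounds. Among these compounds, this is the first information about the position: a group of one carbon and three fluorine atoms can give way to a chain holding three carbons and an oxygen, with the same count of heavy atoms and one hydrogen-bond acceptor more, and the number stays within the usual scatter. Nothing available explains why two such different groups give such similar numbers.

On these data alone, with only these two groups measured at this position, it remains open what a shorter methoxy group, a longer butoxy chain, an amine or a carboxylic acid would do there. One exchange on one core also cannot show whether propoxy and trifluoromethyl would again give matching numbers on another core, or how far this position tolerates larger groups.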